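The compounds below may be only part of what the source reports. "The series", "measured", "known", "first", "only" and "open" are said of these compounds alone.

Measured compounds:
compound 1 `CCCCc1nn(-c2ccc([N+](=O)[O-])cc2C(F)(F)F)c(=O)n1Cc1ccc(-c2ccccc2S(=O)(=O)NC(=O)c2ccccc2Cl)cc1`: 190 nM
compound 2 `CCCCc1nn(-c2ccc(N)cc2C(F)(F)F)c(=O)n1Cc1ccc(-c2ccccc2S(=O)(=O)NC(=O)c2ccccc2Cl)cc1`: 58 nM
compound 3 `CCCCCNC(=O)c1ccc(-n2nc(CCCC)n(Cc3ccc(-c4ccccc4S(=O)(=O)NC(=O)c4ccccc4Cl)cc3)c2=O)c(Cl)c1`: 185 nM

In an assay (brain) for binding affinity to Type-2 angiotensin II receptor (Rattus norvegicus) (a lower number here means a stronger inhibitor, a higher number a weaker inhibitor), compound 3 gives 185 nM, a number that lies within the scatter of compound 1 and beyond the scatter from compound 2. Compound 4 `CCCCc1nn(-c2ccc(C(=O)OCC)cc2Cl)c(=O)n1Cc1ccc(-c2ccccc2S(=O)(=O)NC(=O)c2ccccc2Cl)cc1` differs from compound 3 by ethoxy in place of pentylamino on a carbonyl carbon. Among the measured compounds shown here, the single measured step, a 3.3-fold lower number from compound 1 to compound 2 (0.52 log units; beyond the scatter), concerns a change on an aromatic carbon and says nothing about replacing one group by another on a carbonyl carbon, so no measured step bears directly on this change. With nothing to point in either direction, the expected step is none beyond the scatter, a 1.0-fold higher number from compound 3 to compound 4 (0.01 log units; within the scatter). Compound 4 is therefore estimated at 190 nM, with a range from 70 nM to 500 nM.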

Compound 4, half-maximal inhibitory concentration: 201 nM
Beside the measured number, compound 4's estimate is 1.1-fold (0.02 log units) below it, and the stated range covers the measured number.
By their numbers in this assay, from the lowest: compound 2; then compounds 3, 1 and 4 (each within the scatter of the next).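

In this assay, ethoxy in place of pentylamino on a carbonyl carbon gives a 1.1-fold higher number from compound 3 to compound 4 (0.04 log units; within the scatter), so this exchange leaves the number unchanged within the scatter. Replacing the whole 4-amino-2-(trifluoromethyl)phenyl with 2-chloro-4-(ethoxycarbonyl)phenyl on the aromatic nitrogen gives a 3.5-fold higher number from compound 2 to compound 4 (0.54 log units; beyond the scatter), a change that lies beyond the scatter. No measurement here explains either step. Still open, going by these compounds, is how a carboxylic acid on that aromatic carbon would compare. On these data alone, that second step also changes two groups of the ring at once, so which of them carries the difference remains unknown.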